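Working notes: aryl changes on the amide nitrogen

A few compounds are considered here, and "the series" means these few. Any claim that something is new, unique, unknown or untested is made for them only; others in the source may bear on it.

Measured compounds in an assay on isolated protein for inhibition of histone deacetylase 4 (Homo sapiens), with a stated time of 1 h; on this read-out lower numbers stand for stronger inhibition and higher numbers for weaker inhibition:
- compound 1, `Cc1ccc(NC(=O)COc2ccc3cc(/C=C4/SC(=O)NC4=O)ccc3c2)cc1`, gives 1700 nM
- compound 2, `O=C(COc1ccc2cc(/C=C3/SC(=O)NC3=O)ccc2c1)Nc1ccc(Br)cc1F`, gives 1900 nM
- compound 3, `COc1cccc(NC(=O)COc2ccc3cc(/C=C4/SC(=O)NC4=O)ccc3c2)c1`, gives 1600 nM

On the numbers shown, compound 2 sits alongside the other two: a 1.1-fold higher number from compound 1 to compound 2 (0.05 log units; within the scatter) and a 1.2-fold lower number from compound 2 to compound 3 (0.07 log units; within the scatter), both of them within the scatter, as is a 1.1-fold lower number from compound 1 to compound 3 (0.03 log units; within the scatter). Across these three, exchanging one aryl group for another on the amide-type nitrogen has not moved this assay beyond the scatter.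

Compound 4, `O=C(COc1ccc2cc(/C=C3/SC(=O)NC3=O)ccc2c1)Nc1c(F)cc(F)cc1Br`, is not yet measured. Relative to compound 2 the change is 2-bromo-4,6-difluorophenyl in place of 4-bromo-2-fluorophenyl on an amide-type nitrogen. Going by the values given here, the steps that bear on it are the three aryl exchanges above, all of them within the scatter; the one that touches the same 4-bromo-2-fluorophenyl group, a 1.2-fold lower number from compound 2 to compound 3 (0.07 log units; within the scatter), is likewise within the scatter. No step beyond the scatter is therefore expected in this assay in either direction.

For compound 4 the expected value in this assay is 1900 nM, with a range of 1000 nM to 3600 nM. The expected step, no change at the digits printed from compound 2 to compound 4 (within the scatter), is an estimate resting only on the within-scatter steps of compounds 1, 2 and 3.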

Compound 4, half-maximal inhibitory concentration: 1100 nM
Compound 4: middle estimate off by 1.7-fold (0.24 log units), on the high side; measured number inside the range.
By their numbers in this assay, from the lowest: compounds 4, 3, 1 and 2 (each within the scatter of the next).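

The 2-bromo-4,6-difluorophenyl group carries one more fluorine than 4-bromo-2-fluorophenyl, and in this assay this exchange on the amide-type nitrogen stays within the scatter (a 1.7-fold lower number from compound 2 to compound 4 (0.24 log units; within the scatter)). Going by these compounds alone, the same holds against the other two aryl groups (a 1.5-fold lower number from compound 3 to compound 4 (0.16 log units; within the scatter); a 1.5-fold lower number from compound 1 to compound 4 (0.19 log units; within the scatter)), so the position now reads as flat across four aryl groups, including one with two fluorines and a bromine, a combination the earlier compounds did not cover. No supporting measurement accompanies these numbers, so nothing here accounts for them.

All four compounds carry a substituted phenyl on this nitrogen, which leaves open how the position responds to something else there, such as a cyclohexyl ring, a chain ending in an amine or a chain ending in a carboxylic acid. Also open, from the compounds shown here alone, is whether any aryl exchange at this position can produce a step beyond the scatter in this assay at all.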